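Replacing an Acrylamide Group in a Growth Inhibition Series

A few compounds are considered here, and "the series" means these few. Any claim that something is new, unique, unknown or untested is made for them only; others in the source may bear on it.

Measured values, all of them limits:
Compound 1 `C=CC(=O)NCc1ccc(C(=O)Nc2ccc(C)c(Nc3nccc(-c4cccnc4)n3)c2)cc1` gives > 10000 nM
Compound 2 `C=CC(=O)NCc1cccc(C(=O)Nc2ccc(C)c(Nc3nccc(-c4cccnc4)n3)c2)c1` gives > 10000 nM
Compound 3 `CCC(=O)Nc1cc(C(=O)Nc2ccc(C)c(Nc3nccc(-c4cccnc4)n3)c2)cc(C(F)(F)F)c1` gives > 10000 nM

In an ADME assay on BaF3 cells (Mus musculus) for cytotoxicity, read by CellTiter-Glo and CCK-8 assay, with a stated time of 72 h (on this read-out higher numbers stand for weaker inhibition of growth and lower numbers for stronger inhibition of growth), compound 1 gives > 10000 nM, which is a limit and not a number. Compound 1 therefore has no exact place on the scale. Compound 2 and compound 3 offer no finer comparison, and the whole picture so far is the limit of > 10000 nM in this assay, at which 3 of the 3 values shown sit.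

Compound 4 `Cc1ccc(NC(=O)c2ccc(CNCCN(C)C)cc2)cc1Nc1nccc(-c2cccnc2)n1` keeps the core of compound 1 and changes one group: 2-(dimethylamino)ethyl in place of vinylcarbonyl on an amine nitrogen. In words, 2-(dimethylamino)ethyl stands in place of vinylcarbonyl on an amine nitrogen. Within the data shown here, no two measured compounds differ in just one place, and no measured step is available to size this change.

The expected change, an at least 1.2-fold lower number from compound 1 to compound 4 (0.09 log units; that floor lies within the scatter), is small: a modest move toward stronger inhibition of growth, or none beyond the scatter. This expectation rests on compound 1, which reads > 10000 nM as a limit. A result at the same limit would be no surprise.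

In this assay the estimated value for compound 4 is 8000 nM, with an expected range from 3000 nM to 20000 nM.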

Compound 4, concentration for 50% growth inhibition: > 10000 nM
Compound 4 gave a limit, no number; the forecaster's own chance of this, stated with the estimate: 60%; middle value at least 1.2-fold (0.09 log units) from the limit.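

In this assay compound 4 gives > 10000 nM, which is a limit and not a number. Among these compounds, compound 1 also reads only as a limit, so no step from compound 1 to compound 4 can be read. Whether 2-(dimethylamino)ethyl in place of vinylcarbonyl changes growth inhibition at all stays open, with every compound shown at one reading: the limit of > 10000 nM in this assay, at which 4 of the 4 values shown sit.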